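Dipropylamino Replaces the Piperidinylethyl Tail on the Amide Aryl

The compounds below may be only part of what the source reports. "The series", "measured", "known", "first", "only" and "open" are said of these compounds alone.

The series rests on two measured compounds. Compound 1 `CCN(Cc1ccccn1)c1ccc(C(=O)N2CCc3ccc(OS(N)(=O)=O)cc3C2)cc1` gives 87.7% in an assay on HEK293 cells for inhibition of Steryl-sulfatase (Homo sapiens), tested at 1 uM; on this read-out higher numbers stand for a stronger effect at the one concentration tested and lower numbers for a weaker effect. Compound 2 `CN(CCN1CCCCC1)c1ccc(C(=O)N2CCc3ccc(OS(N)(=O)=O)cc3C2)cc1` gives 26.8% in the same assay, and this is the lowest of the two numbers, its nearest neighbour being compound 1. Within the data shown here, the only measured step, a number 60.9 percentage points lower from compound 1 to compound 2 (beyond the scatter), shows how strongly the group on this aromatic carbon can move the read-out.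

Compound 3 `CCCN(CCC)c1ccc(C(=O)N2CCc3ccc(OS(N)(=O)=O)cc3C2)cc1` differs from compound 2 by dipropylamino in place of methyl(2-(piperidin-1-yl)ethyl)amino on an aromatic carbon. Among the measured compounds shown here, no measured step covers this exact change; the single step from compound 1 to compound 2 bears on it only by showing that exchanging the amino substituent at this position can shift the read-out by a large amount, and that compound 2 itself sits at the low end. Given that compound 2 stands at 26.8% and compound 1 at 87.7%, compound 3 is expected to move upward, with an estimated step of a number 38.2 percentage points higher from compound 2 to compound 3 (beyond the scatter). The estimate for compound 3 is therefore 65%, within a range from 35% to 92%.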

Compound 3, a percentage reported as inhibition, at one concentration (the size of the read-out at that concentration, not a potency): 84.7%
Compound 3: the middle estimate sits 19.7 percentage points below what was measured; the measured number falls inside the stated range.
By their numbers in this assay, from the lowest: compound 2; then compounds 3 and 1 (each within the scatter of the next).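

Exchanging methyl(2-(piperidin-1-yl)ethyl)amino for dipropylamino on this aromatic carbon gives a number 57.9 percentage points higher from compound 2 to compound 3 (beyond the scatter) in this assay, so the low read-out of compound 2 is not shared by every amino substituent at this place. The exchange of ethyl((pyridin-2-yl)methyl)amino for dipropylamino gives a number 3 percentage points lower from compound 1 to compound 3 (within the scatter), which shows that a substituent with no ring at all can match the group bearing the pyridine ring in this single-concentration read-out. Among the three compounds, only compound 2 carries the six-membered non-aromatic ring, and this one example goes with the low read-out, though it cannot separate the effect of that ring from the effect of the chain that carries it.

Nothing available here accounts for the low read-out of compound 2. From the compounds shown here alone, it remains open whether a morpholine ring on the same ethyl chain would also give a low read-out, and whether a longer chain such as dibutylamino would keep the read-out of compound 3, while a single concentration leaves any difference in potency between compound 1 and compound 3 unresolved.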